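Methyl on the anilino ring of compound 2

The source may report more compounds than this note shows. Statements on the series, on what has been measured and on what is new or still open speak of the compounds shown alone.

Measured compounds:
compound 1 `Nc1ccccc1NC(=O)/C=C/c1ccc(Cn2cnc3c(Nc4cccc(Cl)c4)nc(Cl)nc32)cc1` — 7.11%
compound 2 `Nc1ccccc1NC(=O)/C=C/c1ccc(Cn2cnc3c(Nc4ccccc4)nc(Cl)nc32)cc1` — 2.05%
compound 3 `Nc1ccccc1NC(=O)c1ccc(Cn2cnc3c(Nc4ccccc4)nc(Cl)nc32)cc1` — 42.7%

In a functional assay on NCI-H460 cells (Homo sapiens) for antiproliferative activity, read by CCK-8 assay, with a stated time of 72 h, tested at 2 uM (a higher number here means a stronger effect of the compound at the concentration tested, a lower number a weaker effect), compound 2 gives 2.05%, at the low end of the three numbers; compound 1 differs from it only within the scatter, while compound 3 stands well apart. The step of a number 5.1 percentage points lower from compound 1 to compound 2 (within the scatter) is within the scatter; the step of a number 40.7 percentage points higher from compound 2 to compound 3 (beyond the scatter) is large and beyond it.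

Compound 4 `Cc1ccc(Nc2nc(Cl)nc3c2ncn3Cc2ccc(/C=C/C(=O)Nc3ccccc3N)cc2)cc1` differs from compound 2 by methyl in place of hydrogen on an aromatic carbon. Within the data shown here, only the step from compound 1 to compound 2 touches the same anilino ring, and it stayed within the scatter, so no step beyond the scatter is expected here; the amide side of the molecule, which drove the large step to compound 3, is unchanged.

Compound 4 is therefore expected at 5%, in the range -5% to 18%. The expected step is a number 3 percentage points higher from compound 2 to compound 4 (within the scatter).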

Compound 4, a percentage reported as inhibition, at one concentration (the size of the read-out at that concentration, not a potency): 31.3%
The estimate for compound 4 lay 26.3 percentage points below the measured number, outside the stated range (above it).
By their numbers in this assay, from the lowest: compounds 2 and 1 (each within the scatter of the next); then compound 4; then compound 3.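

In this assay the anilino ring is not a silent position: methyl para to a large group gives a number 29.3 percentage points higher from compound 2 to compound 4 (beyond the scatter). Replacing 3-chlorophenyl with 4-methylphenyl gives a number 24.2 percentage points higher from compound 1 to compound 4 (beyond the scatter), a change of both group and place, so the two contributions cannot be separated. No available evidence bears on the origin of this step. Open, going by these compounds, is whether ethyl or methoxy in that place gives a similar number. Also open, on these data alone, is whether 4-methylphenyl raises the number with the shorter amide side of compound 3.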